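Adding a nitrooxy chain to compound 2

The compounds below may be only part of what the source reports. "The series", "measured", "known", "first", "only" and "open" are said of these compounds alone.

Measured so far in a functional assay on HeLa cells (Homo sapiens) for cytotoxicity, read by resazurin assay, with a stated time of 72 h; on this read-out higher numbers stand for weaker inhibition and lower numbers for stronger inhibition
compound 1 (`O=C(/C=C/c1ccc(OCCCCCO[N+](=O)[O-])c(O)c1)OCCCCCO[N+](=O)[O-]`) gives 5730 nM
compound 2 (`COc1cc(/C=C/C(=O)OCCCCCO[N+](=O)[O-])ccc1O`) gives 13400 nM

Compound 2 has the higher number of the two, meaning weaker inhibition, and its gap to compound 1 lies beyond the usual scatter. Compound 3 (`COc1cc(/C=C/C(=O)OCCCCCO[N+](=O)[O-])ccc1OCCCCCO[N+](=O)[O-]`) differs from compound 2 by one change (5-(nitrooxy)pentyl in place of hydrogen on an oxygen on an aromatic ring) with 5-(nitrooxy)pentyl in place of hydrogen on an oxygen on an aromatic ring. Compound 1 also carries 5-(nitrooxy)pentyl on an oxygen on an aromatic ring (5730 nM), so a moderate step towards a lower number is expected in this assay. This expectation amounts to an estimated step (a 2.1-fold lower number from compound 2 to compound 3 (0.31 log units; beyond the scatter)) that may still prove small. For compound 3 the estimated value is 6500 nM (expected range 2500 nM to 15000 nM).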

Compound 3, half-maximal inhibitory concentration: > 50000 nM
Compound 3: only a limit was reported; the forecaster's own chance of this, stated with the estimate: 5%; at least 7.6-fold (0.88 log units) between middle value and limit.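

Putting 5-(nitrooxy)pentyl on the aromatic oxygen of compound 2 weakens inhibition in this assay, giving an at least 3.7-fold higher number from compound 2 to compound 3 (0.57 log units; beyond the scatter), and methyl in place of hydrogen on an aromatic oxygen of compound 1 gives an at least 8.7-fold higher number from compound 1 to compound 3 (0.94 log units; beyond the scatter). Compounds 1 and 2 each keep a free hydroxy on the aromatic ring, while compound 3, the weakest of the three, has none. The value of compound 3 is a limit, not a number: the limit of > 50000 nM in this assay, at which 1 of the 3 values shown sits.

From the compounds shown here alone, how far compound 3 truly lies remains open. So does whether an amine or a carboxylic acid in place of the nitrooxy group at the end of the chain would behave alike.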